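Aryl ether to phenyl thioether on the shared core

This account rests on a few compounds, and the source may have more. Where it says the series, first, only, none or still open, it means among the compounds named here.

Measured so far:
Compound 1 `CC(C)(Oc1ccccc1Br)C1OCC(C/C=C\CCC(=O)O)C(c2cccnc2)O1` gives 29 nM in an assay for inhibition of Thromboxane-A synthase (Homo sapiens), using microsomes; a lower number here means a stronger inhibitor, a higher number a weaker inhibitor.
Compound 2 `CC(C)(Oc1ccc(F)cc1[N+](=O)[O-])C1OCC(C/C=C\CCC(=O)O)C(c2cccnc2)O1` gives 20 nM in this assay.

Compound 2 holds the lowest of the two numbers, but its nearest neighbour is compound 1, and the step of a 1.5-fold lower number from compound 1 to compound 2 (0.16 log units; within the scatter) lies within the scatter, so the two aryl groups on the oxygen are not told apart by these data.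

Compound 3 `CC(C)(Sc1ccccc1)C1OCC(C/C=C\CCC(=O)O)C(c2cccnc2)O1` is not yet measured. Its change from compound 2 is: a group of 7 heavy atoms (6 carbon, 1 sulfur; one six-membered aromatic ring of carbon only) in place of a group of 11 heavy atoms (6 carbon, 1 nitrogen, 3 oxygen, 1 fluorine; one six-membered aromatic ring of carbon only), on a saturated chain carbon bound to two saturated chain carbons and a saturated ring carbon. Among the compounds with values here, only one measured step touches this position, the exchange of one aryl group for another on the oxygen, which gave a 1.5-fold lower number from compound 1 to compound 2 (0.16 log units; within the scatter). Within the data shown here, no measured pair speaks to the exchange of the oxygen for sulfur, nor to the smaller group that enters. Among the measured compounds shown here, with the single relevant step within the scatter, no step beyond the scatter is expected in this assay from compound 2 to compound 3, though the range is kept wide for a change without precedent. For compound 3 the expected value in this assay is 40 nM, with a range of 12 nM to 130 nM. The expected step of a 2.0-fold higher number from compound 2 to compound 3 (0.30 log units; within the scatter) is accordingly small.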

Compound 3, half-maximal inhibitory concentration: 40 nM
Estimate against measurement, compound 3: no gap at the digits printed, within the range that was stated.
By their numbers in this assay, from the lowest: compounds 2, 1 and 3 (each within the scatter of the next).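

Notes on the position at the saturated chain carbon: in this assay, phenylsulfanyl brings sulfur to the linking place and a ring with no substituents, and the result is a 2.0-fold higher number from compound 2 to compound 3 (0.30 log units; within the scatter) against the nitro and fluoro compound, with a 1.4-fold higher number from compound 1 to compound 3 (0.14 log units; within the scatter) against the 2-bromophenoxy compound. Neither step leaves the scatter, so the three groups are not told apart by this read-out, and this now holds for a change of linking atom and a smaller group as well as for an exchange of one aryl ether for another. No measurement bearing on why these compounds fall so close together is at hand.

The step to compound 3 changes the linking atom and the ring substituents together, and a phenoxy group with a bare ring or a 2-bromophenylsulfanyl group would be needed to read each change alone. Also open, as far as these compounds go, is whether an amine or a carboxylic acid on the aromatic ring, or a longer chain between that ring and the saturated chain carbon, would give a step beyond the scatter.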